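Pyrazolyl in Place of Vinyl on the Shared Core

The source may hold more compounds than are shown below. What is called first, only, known or untested is meant among the compounds shown, and "the series" means these compounds.

Compound 1 `O=C(O)c1cn(-c2nccs2)c2nc(-c3ccccc3)ccc2c1=O` gives 6.33 ug/mL in a functional assay on P388 cells (Mus musculus) for cytotoxicity; a lower number here means a stronger inhibitor, a higher number a weaker inhibitor.
Compound 2 `C=Cc1ccc2c(=O)c(C(=O)O)cn(-c3nccs3)c2n1` reaches only the limit > 1 ug/mL in this assay.

Compound 2 thus stands at a limit rather than at a number in this assay. The step that the limit leaves unreadable from compound 1 to compound 2 cannot be sized because of the limit of > 1 ug/mL in this assay, at which 1 of the 2 values shown sits. Compound 3 `O=C(O)c1cn(-c2nccs2)c2nc(-c3cc[nH]n3)ccc2c1=O` carries 1H-pyrazol-3-yl in place of vinyl on an aromatic carbon. Within the data shown here, no measured step reads clearly on this change, so compound 3 is expected to land near 5 ug/mL, within 1 ug/mL to 30 ug/mL. The step that the limit leaves unreadable from compound 2 to compound 3 is expected to stay within the reach of the scatter.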

Compound 3, half-maximal inhibitory concentration: 4.34 ug/mL
Beside the measured number, compound 3's estimate is 1.2-fold (0.06 log units) above it, within the range that was stated.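

Among these compounds, with 1H-pyrazol-3-yl in place of phenyl on the aromatic carbon next to the ring nitrogen, this assay gives the first readable step at this position: a 1.5-fold lower number from compound 1 to compound 3 (0.16 log units; within the scatter). Across this one change, a five-membered aromatic ring with 2 hetero atoms and a phenyl therefore cannot be told apart. The steps involving compound 2 cannot be read because its value is a limit: the limit of > 1 ug/mL in this assay, at which 1 of the 3 values shown sits.

Where vinyl stands against either ring therefore remains open. So does what an amine or a longer alkyl chain would give at this position.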